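Removing the ring hydroxy from compound 2

The source may hold more compounds than are shown below. What is called first, only, known or untested is meant among the compounds shown, and "the series" means these compounds.

Three compounds of this series have numbers in a functional assay on RAW264.7 cells (Mus musculus) for inhibition, read by Griess assay, with stated times of 30 min and 24 h; a lower number here means a stronger inhibitor, a higher number a weaker inhibitor. Compound 1 `C=C1C(=O)O[C@H]2C[C@@H](C)C(CCC(C)O)=CC[C@H]12` gives 870 nM. Compound 3 `C=C1C(=O)O[C@@H]2C[C@H](C)[C@]3(CCC(C)O)O[C@@H]3C[C@H]12` gives 18900 nM. Compound 2 `CC(=O)CCC1=C[C@@H](O)[C@@H]2[C@H](C)C(=O)O[C@@H]2C[C@@H]1C` gives 21900 nM, the highest of the three numbers; its value and that of compound 3 lie within the scatter of each other, while compound 1 stands well apart, beyond the scatter.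

Compound 4 `CC(=O)CCC1=CC[C@@H]2[C@H](C)C(=O)O[C@@H]2C[C@@H]1C` differs from compound 2 in one place: hydrogen in place of hydroxy on a saturated ring carbon. Among the measured compounds shown here, no pair among the measured compounds differs in one place, so no single step is known that would calibrate this change. Compound 1, which also carries no hydroxy on the seven-membered ring, differs from compound 2 in several other places as well, so its value cannot be tied to this change alone.

The expectation is a modest move toward a lower number, expected as a 1.8-fold lower number from compound 2 to compound 4 (0.26 log units; within the scatter), though a change no larger than the scatter would be no surprise. Compound 4 is therefore estimated at 12000 nM, in a range from 4000 nM to 40000 nM.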

Compound 4, half-maximal inhibitory concentration: 64900 nM
Compound 4: the middle estimate sits 5.4-fold (0.73 log units) below what was measured; the measured number lies above the stated range.
By their numbers in this assay, from the lowest: compound 1; then compounds 3 and 2 (each within the scatter of the next); then compound 4.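

In this assay, hydrogen in place of hydroxy on a saturated ring carbon of the seven-membered ring gives a 3.0-fold higher number from compound 2 to compound 4 (0.47 log units; beyond the scatter), and this step lies beyond the scatter. Among the compounds shown here, it is the first single-change reading, and it runs against the lower number expected for this change: at this position, with the 2-acetylethyl group present, the hydroxy of compound 2 goes with the stronger inhibition. Nothing on hand gives a reason for this step.

From the compounds shown here alone, it remains open whether the hydroxy itself is what counts, or whether a methoxy, an acetate ester or an amine on the same ring carbon would also keep the lower number. Going by these compounds, it also remains open whether the step would keep its size and direction on a compound with another chain in place of the 2-acetylethyl group.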